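Alkene Tails and Leukotriene Receptor Inhibition at One Dose

The source may hold more compounds than are shown below. What is called first, only, known or untested is meant among the compounds shown, and "the series" means these compounds.

Compound 1, `CCCCc1cc(C(C)=O)c(O)cc1OCCCCC#N`: 41%
Compound 2, `C=CCc1cc(C(C)=O)c(O)cc1OCCCCC#N`: 92%
Compound 3, `C=CCc1cc(C(C)=O)c(O)cc1OCCCCCCC`: 31%

Three compounds were tested in an assay on isolated protein for inhibition of leukotriene B4 receptor 1 (Homo sapiens), tested at 10 uM; on this read-out higher numbers stand for more inhibition at the one concentration tested (going by the name of the read-out) and lower numbers for less inhibition. The step of a number 51 percentage points higher from compound 1 to compound 2 (beyond the scatter) came with this change: vinyl in place of propyl on a saturated chain carbon bound to an aromatic carbon. The step of a number 61 percentage points lower from compound 2 to compound 3 (beyond the scatter) came with a change on the chain bound to the aromatic oxygen. Compound 4, `C=CCCCCOc1cc(O)c(C(C)=O)cc1CC=C`, has not yet been measured in this assay. It differs from compound 3 by vinyl in place of propyl on a saturated chain carbon, four bonds along the chain from an oxygen on an aromatic ring. This is the same kind of change as that from compound 1 to compound 2, but at a different place: there on a saturated chain carbon bound to an aromatic carbon, here on a saturated chain carbon four bonds along the chain from an oxygen on an aromatic ring. The difference between the cores of compound 3 and compound 1 is not broken down here. Because the earlier step of a number 51 percentage points higher from compound 1 to compound 2 (beyond the scatter) was large but sits at another place, a smaller rise is expected, estimated as a number 14 percentage points higher from compound 3 to compound 4 (beyond the scatter). Compound 4 is expected to give about 45%, between 20% and 70%.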

Compound 4, a percentage reported as inhibition, at one concentration (the size of the read-out at that concentration, not a potency): 73%
Compound 4: the middle estimate sits 28 percentage points below what was measured; measured number above the stated range.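

In this assay, vinyl in place of propyl gives a number 42 percentage points higher from compound 3 to compound 4 (beyond the scatter), while vinyl in place of cyano at that same place gives a number 19 percentage points lower from compound 2 to compound 4 (beyond the scatter). Vinyl in place of propyl thus brought a rise of similar size on two cores, although it sat at a different place on each: the same change on two cores in this assay, a number 51 percentage points higher (beyond the scatter) from compound 1 to compound 2 and a number 42 percentage points higher (beyond the scatter) from compound 3 to compound 4, 9 percentage points apart, within the scatter of two such steps This is only two cases, so it does not show that the rise would hold on other cores or at other places, and it does not explain the rise.

The compounds shown leave open what an amine or a carboxylic acid would do at this place on the chain. A longer chain ending in vinyl also remains an open question.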